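Compound 4 and the Step from Compound 1

The source may report more compounds than this note shows. Statements on the series, on what has been measured and on what is new or still open speak of the compounds shown alone.

Values in an ADME assay on microsomes from liver (Mus musculus) for metabolic stability, with a stated time of 40 min, tested at 10 uM (on this read-out lower numbers stand for a less stable compound and higher numbers for a more stable compound), for the measured compounds
Compound 1 `CCS(=O)(=O)Nc1ccc(Oc2ccc(F)cc2)c(-c2cn(C)c(=O)c3cncn23)c1` gives 65.6%
Compound 2 `CCS(=O)(=O)Nc1ccc(Oc2ccc(-c3c(C)noc3C)cc2)c(-c2cn(C)c(=O)c3cncn23)c1` gives 48.2%
Compound 3 `Cn1cc(-c2cc(NS(C)(=O)=O)ccc2Oc2ccc(F)cc2)n2cncc2c1=O` gives 75.9%

Compound 1 stands second highest of these three numbers, with compound 3 above it and compound 2 below it, both gaps beyond the scatter. Compound 4 `CCS(=O)(=O)Nc1ccc(Oc2cc(F)c(F)c(F)c2)c(-c2cn(C)c(=O)c3cncn23)c1` has not yet been measured. Its change from compound 1 3,4,5-trifluorophenyl in place of 4-fluorophenyl on an oxygen on an aromatic ring puts 3,4,5-trifluorophenyl in place of 4-fluorophenyl on an oxygen on an aromatic ring.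

Two measured steps offer guidance. The closer one is a number 17.4 percentage points lower from compound 1 to compound 2 (beyond the scatter) with 3,5-dimethyl-1,2-oxazol-4-yl in place of fluoro on an aromatic carbon, a modest step beyond the scatter. The other is a number 10.3 percentage points higher from compound 1 to compound 3 (beyond the scatter) with hydrogen in place of methyl on a saturated chain carbon bound to a sulfonyl sulfur, a different change that says little here. Neither step shows what this exchange of fluorinated groups does, so no step beyond the scatter is expected in this assay for now. The expected step is a number 3.6 percentage points lower from compound 1 to compound 4 (within the scatter) by this estimate. Compound 4 is expected at 62% within an estimated range of 46% to 76% for now.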

Compound 4, percent of the compound remaining: 36%
Estimate against measurement, compound 4: 26 percentage points above, and the stated range ends above it.
By their numbers in this assay, from the lowest: compound 4; then compound 2; then compound 1; then compound 3.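

In this assay, the exchange of 4-fluorophenyl for 3,4,5-trifluorophenyl gives a number 29.6 percentage points lower from compound 1 to compound 4 (beyond the scatter), so this aryl group on the oxygen responds even when the ring stays and only fluorine atoms are added. The earlier change on this ring swapped the fluoro for a whole 3,5-dimethyl-1,2-oxazol-4-yl group, giving a number 17.4 percentage points lower from compound 1 to compound 2 (beyond the scatter); compound 4 shows that a step of the same direction, also beyond the scatter, does not require a new ring on this aryl group. Nothing shown here accounts for the lower number of compound 4.

The compounds shown do not separate the contribution of each added fluorine atom, so it stays open how a single added fluorine would read. Also open, from the compounds shown here alone, is how this position would respond to a group without fluorine, such as a methoxy, a nitrile or a morpholine.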